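Three compounds measured and one untested sulfanyl riboside

The source may report more compounds than this note shows. Statements on the series, on what has been measured and on what is new or still open speak of the compounds shown alone.

This account follows the step from compound 2 `OC[C@H]1OC(n2cnc3c(Nc4ccccc4)nccc32)[C@H](O)[C@@H]1O` to compound 4 `OC[C@H]1OC(n2cnc3c(S)nccc32)[C@H](O)[C@@H]1O`. In a functional assay (Homo sapiens) for inhibition of Nucleic Acid, tested at 100 uM (a higher number here means more inhibition at the concentration tested (going by the name of the read-out), a lower number less inhibition), compound 2 gives 4%, level at the digits shown with compound 1 `CSc1[nH]ccc2ncnc1-2`, which gives 4% in this assay; together these two are the lowest of the three numbers. Compound 3 `c1ccc(Nc2[nH]ccc3ncnc2-3)cc1` gives 12% in this assay, a difference from compound 2 that lies within the scatter. Within the data shown here, no two measured compounds differ in a single place, so no measured step is available. The change from compound 2 to compound 4 is sulfanyl in place of anilino on an aromatic carbon. Because compound 1, which lacks an anilino group, gives 4%, no step beyond the scatter is expected. Compound 4 is estimated at 5%, between -5% and 15%. The expected step is a number 1 percentage points higher from compound 2 to compound 4 (within the scatter).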

Compound 4, a percentage reported as inhibition, at one concentration (the size of the read-out at that concentration, not a potency): 6%
Compound 4: the middle estimate sits 1 percentage points below what was measured; the range from low to high includes it.
By their numbers in this assay, from the lowest: compounds 1, 2, 4 and 3 (each within the scatter of the next).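

In this assay, among these compounds, sulfanyl in place of anilino on an aromatic carbon gives a number 2 percentage points higher from compound 2 to compound 4 (within the scatter), the first step in this set that changes a single place. At this carbon, next to the ring nitrogen, losing the anilino group and its six-membered aromatic ring therefore leaves the number within the scatter. Nothing given here offers an explanation for this result. As far as these compounds go, it remains open whether any group at this carbon can move the number beyond the scatter. An amine or a carboxylic acid in place of sulfanyl would test that.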